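Legumain nitrile series: aryl swap on the weaker epimer

The source may report more compounds than this note shows. Statements on the series, on what has been measured and on what is new or still open speak of the compounds shown alone.

Measured compounds in an assay on isolated protein for inhibition of legumain (Homo sapiens), with stated times of 2 min and 60 min; on this read-out lower numbers stand for stronger inhibition and higher numbers for weaker inhibition:
Compound 1 `C[C@@H](C(=O)N[C@H](C#N)CC(N)=O)N(Cc1ccc(-c2ccc(F)c(F)c2)cc1)S(C)(=O)=O` gives 252 nM.
Compound 2 `C[C@H](C(=O)N[C@H](C#N)CC(N)=O)N(Cc1ccc(-c2ccc(F)c(F)c2)cc1)S(C)(=O)=O` gives 6300 nM.
Compound 3 `CCC[C@@H](C(=O)N[C@H](C#N)CC(N)=O)N(Cc1ccc(-c2cccc(F)c2F)cc1)S(C)(=O)=O` gives 7750 nM.

Compound 2 stands second highest of the three numbers in this assay. Its nearest neighbour is compound 3, whose value sits within the scatter of that of compound 2; its furthest is compound 1. Among the compounds with values here, the only step between two compounds that differ in one place is a 25-fold higher number from compound 1 to compound 2 (1.40 log units; beyond the scatter), and this rests on the fact that compounds 1 and 2 differ only in the configuration as drawn: the change is one of configuration at the saturated chain carbon, not of the aryl group.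

Compound 4 `C[C@H](C(=O)N[C@H](C#N)CC(N)=O)N(Cc1ccc(-c2cccc(C(F)(F)F)c2)cc1)S(C)(=O)=O` keeps the configuration of compound 2 and alters the distal ring: 3-(trifluoromethyl)phenyl in place of 3,4-difluorophenyl on an aromatic carbon. Within the data shown here, no measured step in this set touches the aryl ring at that position, so nothing here bears directly on the change. Among the measured compounds shown here, compound 3 carries a differently substituted fluorinated ring together with a propyl chain and a value close to that of compound 2, but that pair differs in more than one place and supports no step.

For the measured compounds named here, with no step that bears on the aryl change, the expectation for compound 4 in this assay is a number near that of compound 2, with a 1.1-fold lower number from compound 2 to compound 4 (0.02 log units; within the scatter) not beyond the scatter. Compound 4 is therefore estimated at 6000 nM, within 2000 nM to 18000 nM.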

Compound 4, half-maximal inhibitory concentration: > 10000 nM
Compound 4 was reported as a limit; the forecaster's own chance of this, stated with the estimate: 10%; middle value at least 1.6-fold (0.22 log units) away from the limit.
By their numbers in this assay, from the lowest: compound 1; then compounds 2 and 3 (each within the scatter of the next). At a limit, above all of these: compound 4.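

In this assay compound 4 is reported only as a limit, > 10000 nM. Within the data shown here, replacing 3,4-difluorophenyl with 3-(trifluoromethyl)phenyl on an aromatic carbon, para to a large group, gives an at least 1.5-fold higher number from compound 2 to compound 4 (0.20 log units; that floor lies within the scatter); this is the first reading of a one-place ring change, and it shows no lower number with the new ring on the configuration of compound 2, although the floor alone does not separate the two compounds. The true size of the step therefore remains unfixed, and a real rise is neither shown nor excluded, because the reading ends at an assay limit: the limit of > 10000 nM in this assay, at which 1 of the 4 values shown sits.

Still open, as far as these compounds go, is what 3-(trifluoromethyl)phenyl gives on the configuration of compound 1, which gives 252 nM with 3,4-difluorophenyl, and whether a ring change would read differently on that epimer than on compound 2. From the compounds shown here alone, also open in this assay is how a carboxylic acid or an amine on the distal ring would read, on either configuration, against the two fluorinated rings compared here.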